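Moving one fluoro group: 4-fluorobenzyl to 2-fluorobenzyl

The compounds below may be only part of what the source reports. "The series", "measured", "known", "first", "only" and "open" are said of these compounds alone.

In a functional assay on QGY7701 cells (Homo sapiens) for cytotoxicity, read by MTT assay, with a stated time of 48 h (a higher number here means a weaker inhibitor, a lower number a stronger inhibitor), compound 1 `O=c1ccoc2cc(OCc3cn(Cc4ccccc4)nn3)ccc12` reads > 100000 nM, which is a limit of the assay and not a number. Compound 2 `O=c1ccoc2cc(OCc3cn(Cc4cccc(Br)c4)nn3)ccc12` gives 17600 nM and compound 3 `O=c1ccoc2cc(OCc3cn(Cc4ccc(F)cc4)nn3)ccc12` gives 14400 nM in the same test. Bromo in place of hydrogen on an aromatic carbon brought an at least 5.6-fold lower number from compound 1 to compound 2 (0.75 log units; beyond the scatter), and fluoro in place of hydrogen brought an at least 6.9-fold lower number from compound 1 to compound 3 (0.84 log units; beyond the scatter). Swapping one substituted ring for the other brought a 1.2-fold lower number from compound 2 to compound 3 (0.09 log units; within the scatter), so those two share the low end of the numbers shown and cannot be told apart.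

Compound 4 `O=c1ccoc2cc(OCc3cn(Cc4ccccc4F)nn3)ccc12` has the same atoms as compound 3, joined differently: 2-fluorophenyl in place of 4-fluorophenyl on a saturated chain carbon bound to an aromatic nitrogen. Among the measured compounds shown here, no measured step moves a fluoro group on its own. The closest guide is a 1.2-fold lower number from compound 2 to compound 3 (0.09 log units; within the scatter), where both the substituent and its place changed and the number stayed within the scatter. A step beyond the scatter is therefore not expected, and the expected change in this assay is a 1.1-fold higher number from compound 3 to compound 4 (0.05 log units; within the scatter). For compound 4 the estimated value is 16000 nM, with an expected range from 6000 nM to 50000 nM.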

Compound 4, half-maximal inhibitory concentration: 36900 nM
Compound 4: middle estimate off by 2.3-fold (0.36 log units), on the low side, and the stated range covers the measured number.
By their numbers in this assay, from the lowest: compounds 3 and 2 (each within the scatter of the next); then compound 4. At a limit, above all of these: compound 1.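

Where the fluoro group sits matters in this assay: 2-fluorophenyl in place of 4-fluorophenyl brought a 2.6-fold higher number from compound 3 to compound 4 (0.41 log units; beyond the scatter), and since the two compounds have the same atoms, joined differently, this step isolates place from kind of substituent. Compound 2 and compound 3 could not be told apart, but 2-fluorophenyl in place of 3-bromophenyl brought a 2.1-fold higher number from compound 2 to compound 4 (0.32 log units; beyond the scatter), so compound 4 stands apart from both of them, although this step changes both the substituent and its place. Adding a single fluoro group to the ring still brought an at least 2.7-fold lower number from compound 1 to compound 4 (0.43 log units; beyond the scatter), so the 2-fluorophenyl group keeps part of the drop seen with the 4-fluorophenyl group, but this step is only a bound, as compound 1 reads at a limit: the limit of > 100000 nM in this assay, at which 1 of the 4 values shown sits.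

The compounds shown leave open whether this sensitivity to place is particular to fluoro, or whether a methoxy group, an amine or a carboxylic acid on the same ring would respond in the same way. They also give no reason why the place matters, since a single cell-based read-out shows the size of the change and not its cause.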